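This account rests on a few compounds, and the source may have more. Where it says the series, first, only, none or still open, it means among the compounds named here.

Compound 1 `CCN(C)c1nc(Cc2c(F)cccc2F)cc(=O)[nH]1`: > 89000 nM
Compound 2 `CCCN(CCC)c1nc(Cc2c(F)cccc2F)cc(=O)[nH]1`: > 78000 nM

In an ADME assay on MT4 cells (Homo sapiens) for cytotoxicity, read by MTT assay, with a stated time of 4 days (a higher number here means that more compound is tolerated, a lower number that less compound is tolerated), compound 2 gives > 78000 nM, which is a limit of the assay rather than a measured number. In this assay compound 1 gives > 89000 nM, likewise a limit. Compound 2 thus stands at a limit on the numbers shown, and the one other value shown is a limit as well, so no ranking of the two can be made.

Compound 3 `CC1CCCCN1c1nc(Cc2c(F)cccc2F)cc(=O)[nH]1` differs from compound 2 by 2-methylpiperidin-1-yl in place of dipropylamino on an aromatic carbon. For the measured compounds named here, the only measured step that touches this position is a step that the two limits leave unreadable from compound 1 to compound 2. Its size cannot be read, since compound 2 sits at a limit (the limit of > 78000 nM in this assay, at which 1 of the 2 values shown sits). Compound 1 sits at a limit too (the limit of > 89000 nM in this assay, at which 1 of the 2 values shown sits). Nothing shown therefore points to a step beyond the scatter in either direction for the change to compound 3.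

Compound 3 is expected to give about 80000 nM, within 40000 nM to 160000 nM. The step this estimate implies, a step that the limit leaves unreadable from compound 2 to compound 3, is expected to fall within the scatter, and the assay may well report only a limit again.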

Compound 3, half-maximal cytotoxic concentration: > 78000 nM
Compound 3 ended at the assay's limit; the forecaster's own chance of this, stated with the estimate: 85%; the middle value lies beyond the limit too.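

For the compounds shown here, compound 1, compound 2 and compound 3 all stand at limits of the assay in this assay, so no step among them can be read. The compounds shown leave open at what concentration any of the three would harm the cells, and whether swapping the amino group on the shared core changes that at all.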